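This account rests on a few compounds, and the source may have more. Where it says the series, first, only, none or still open, it means among the compounds named here.

Working notes on a small set sharing one core, the nitro-substituted benzimidazole linked through a thioether-bearing chain. Three members have numbers in a functional assay on HepG2 cells (Homo sapiens) for cytotoxicity, read by MTT assay, with a stated time of 48 h; on this read-out lower numbers stand for stronger inhibition and higher numbers for weaker inhibition. Compound 1 `O=[N+]([O-])c1ccc2[nH]c(CSCc3nc4cc([N+](=O)[O-])ccc4[nH]3)nc2c1` gives 2250 nM. Compound 2 `O=C(CSCc1nc2cc([N+](=O)[O-])ccc2[nH]1)c1ccc(Br)cc1` gives 2010 nM, the lowest number of the three; against compound 1 the gap lies within the usual scatter, so no order between these two is claimed. Compound 3 `N#Cc1sc(Nc2ccccc2)nc1NC(=O)CSCc1nc2cc([N+](=O)[O-])ccc2[nH]1` gives 9480 nM, which stands beyond the scatter from compound 2 and is the weakest read-out of the set.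

Compound 4 `NC(=S)NNC(=O)CSCc1nc2cc([N+](=O)[O-])ccc2[nH]1` has not yet been measured in this assay. Relative to compound 2 the change is a group of 5 heavy atoms (1 carbon, 3 nitrogen, 1 sulfur; no ring) in place of a group of 7 heavy atoms (6 carbon, 1 bromine; one six-membered aromatic ring of carbon only), on a carbonyl carbon. In words: a group of five heavy atoms (one carbon, three nitrogen, one sulfur; no ring) in place of a group of seven heavy atoms (six carbon, one bromine; one six-membered aromatic ring of carbon only), on a carbonyl carbon.

For the measured compounds named here, no measured pair in the set differs in exactly this way, so the step is estimated only from the spread seen. The piece of compound 2 that leaves carries the group shared with the lower numbers, and compound 3 shows that a chain-linked, donor-rich end can sit at 9480 nM. A step toward a weaker read-out, beyond the scatter, is expected, a 3.2-fold higher number from compound 2 to compound 4 (0.51 log units; beyond the scatter). Compound 4 is expected to give 6500 nM, with a range of 2500 nM to 17000 nM.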

Compound 4, half-maximal inhibitory concentration: 7050 nM
Beside the measured number, compound 4's estimate is 1.1-fold (0.04 log units) below it, within the range that was stated.
By their numbers in this assay, from the lowest: compounds 2 and 1 (each within the scatter of the next); then compounds 4 and 3 (each within the scatter of the next).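

For the compounds shown here, on the carbonyl carbon whose other neighbour is a saturated chain carbon, this assay gives the first step in the set that can be read at a single place: a group of 5 heavy atoms (1 carbon, 3 nitrogen, 1 sulfur; no ring) in place of 4-bromophenyl gives a 3.5-fold higher number from compound 2 to compound 4 (0.54 log units; beyond the scatter), a modest change but one beyond the scatter. The read-out at this position therefore responds to the group on the carbonyl carbon, and the aromatic ring and bromine of 4-bromophenyl are not needed for a measurable number, as compound 4 still has one. No independent evidence bears on this step, and this single pair changes ring, bromine, sulfur and hydrogen-bond donors together.

Which of these parts carries the step remains open. Phenyl without bromine, 4-chlorophenyl, a plain amine or the oxygen counterpart of the sulfur-bearing group on the same carbonyl carbon could separate the loss of bromine, the loss of the ring and the entry of sulfur.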